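Aromatic ring in place of cyclohexyl on a nitrogen on an aromatic ring

The compounds below may be only part of what the source reports. "The series", "measured", "known", "first", "only" and "open" are said of these compounds alone.

Compound 1 `C=CCNc1nc(N)c(C(=O)N=C(N)N)nc1Cl`: 78%
Compound 2 `NC(N)=NC(=O)c1nc(Cl)c(NC2CCCCC2)nc1N`: 92%
Compound 3 `CN1CCN(c2nc(N)c(C(=O)N=C(N)N)nc2Cl)CC1`: 51%

In an assay for inhibition of acid-sensing ion channel 3 (Homo sapiens), read by patch clamp, tested at 20 uM (on this read-out higher numbers stand for more inhibition at the one concentration tested (going by the name of the read-out) and lower numbers for less inhibition), compound 2 stands highest of the three numbers. Its nearest neighbour is reached by the step of a number 14 percentage points higher from compound 1 to compound 2 (beyond the scatter) and its furthest by a number 41 percentage points lower from compound 2 to compound 3 (beyond the scatter). Compound 4 `NC(N)=NC(=O)c1nc(Cl)c(Nc2cccc(Cl)c2)nc1N` differs from compound 2 by 3-chlorophenyl in place of cyclohexyl on a nitrogen on an aromatic ring; one six-membered ring of carbon only gives way to another, non-aromatic to aromatic. The two steps touching compound 2 both bear on this: the modest gain a number 14 percentage points higher from compound 1 to compound 2 (beyond the scatter) and the large loss a number 41 percentage points lower from compound 2 to compound 3 (beyond the scatter). No aromatic group at this nitrogen has been measured, so compound 4 is expected to move only slightly, a number 7 percentage points lower from compound 2 to compound 4 (within the scatter), with the ceiling near. For compound 4 the estimate is 85%, from 65% to 98%.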

Compound 4, a percentage reported as inhibition, at one concentration (the size of the read-out at that concentration, not a potency): 94%
Compound 4: the middle estimate sits 9 percentage points below what was measured; low and high end bracket the measured number.
By their numbers in this assay, from the lowest: compound 3; then compound 1; then compounds 2 and 4 (each within the scatter of the next).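

In this assay an aromatic ring carrying chlorine is accepted on this nitrogen: 3-chlorophenyl in place of cyclohexyl gives a number 2 percentage points higher from compound 2 to compound 4 (within the scatter) and leaves the two rings indistinguishable here. The step from the allyl group, a number 16 percentage points higher from compound 1 to compound 4 (beyond the scatter), shows that the aromatic ring keeps the advantage over allyl that cyclohexyl had. No evidence is available that bears on this result.

As far as these compounds go, whether the chlorine contributes remains open, and a plain phenyl group on this nitrogen would address that. How a benzyl group or a pyridyl ring would read there is also unknown.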